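Methyl added to the fused ring of compound 1

This account rests on a few compounds, and the source may have more. Where it says the series, first, only, none or still open, it means among the compounds named here.

Measured so far in a functional assay on MCF7 cells (Homo sapiens) for antiproliferative activity, read by MTT assay, with a stated time of 48 h; on this read-out higher numbers stand for weaker inhibition and lower numbers for stronger inhibition:
Compound 1 `CS(=O)(=O)c1ccc(Nc2ncc(F)c(Nc3nc4ccccc4s3)n2)cc1`: compound 1 gives 6880 nM
Compound 2 `NS(=O)(=O)c1ccc(Nc2ncc(F)c(Nc3nc4ccccc4s3)n2)cc1`: compound 2 gives > 50000 nM, a limit of the assay

Among the measured compounds shown here, compound 1 carries the only number in this assay; the other value shown is a limit. Compound 2 sits at a limit, (the limit of > 50000 nM in this assay, at which 1 of the 2 values shown sits). For the measured compounds named here, the single measured step, an at least 7.2-fold higher number from compound 1 to compound 2 (0.86 log units; beyond the scatter), concerns the sulfonyl substituent and leaves the fused ring of the core untouched.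

Compound 3 `Cc1ccc2nc(Nc3nc(Nc4ccc(S(C)(=O)=O)cc4)ncc3F)sc2c1` differs from compound 1 by methyl in place of hydrogen on an aromatic carbon. Going by the values given here, no measured step touches that part of the core of compound 1, so the data give no guidance on direction or size for this change. A single methyl on an aromatic carbon is expected to move the number little, if at all, beyond the scatter. Compound 3 is expected to give about 5000 nM, within 1500 nM to 20000 nM. The expected step is a 1.4-fold lower number from compound 1 to compound 3 (0.14 log units; within the scatter).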

Compound 3, half-maximal inhibitory concentration: > 50000 nM
Compound 3: only a limit was reported; the forecaster's own chance of this, stated with the estimate: 10%; middle value at least 10-fold (1.00 log units) from the limit.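

In this assay, methyl in place of hydrogen on an aromatic carbon of the fused ring system gives an at least 7.2-fold higher number from compound 1 to compound 3 (0.86 log units; beyond the scatter), so this part of the core responds to a single added carbon, which the earlier step on the sulfonyl substituent could not show. Compound 3 gives > 50000 nM, which is a limit of the assay and not a number. The full size of the step stays unknown, and compound 3 cannot be ranked against compound 2, because both sit at the same limit: the limit of > 50000 nM in this assay, at which 2 of the 3 values shown sit.

Open, from the compounds shown here alone, is whether any substituent on this carbon costs as much, for instance a fluorine, a methoxy group or an amine. Also open, going by these compounds, is whether a methyl on another carbon of this ring behaves in the same way.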